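Swapping methyl for (4-fluorophenyl)carbamoyl on a shared core

The compounds below may be only part of what the source reports. "The series", "measured", "known", "first", "only" and "open" are said of these compounds alone.

Measured compounds:
compound 1 `COc1ccc2c(c1)C(n1ccccc1=O)=CC(C)(C)O2`, 5.99
compound 2 `CC1(C)C=C(n2ccccc2=O)c2cc(C(=O)c3ccco3)ccc2O1`, 5.92

In a functional assay (trachea) with Rattus norvegicus as the target (a higher number here means a more potent compound, by a factor of ten per unit of this negative logarithm, a lower number a less potent compound), compound 1 gives 5.99, and compound 2 gives 5.92; the two numbers lie within the scatter of each other, as the step of a number 0.07 log units lower from compound 1 to compound 2 (within the scatter) shows. Compound 3 `CC1(C)C=C(n2ccccc2=O)c2cc(OC(=O)Nc3ccc(F)cc3)ccc2O1` is not yet measured. It differs from compound 1 as follows: (4-fluorophenyl)carbamoyl in place of methyl on an oxygen on an aromatic ring. Among the compounds with values here, the only measured step touching the same site of the core is a number 0.07 log units lower from compound 1 to compound 2 (within the scatter), where a larger group in place of methoxy on the aromatic carbon changed nothing beyond the scatter. Within the data shown here, the change to compound 3 is larger and adds a hydrogen-bond donor, but no measured pair speaks to that. Compound 3 is therefore expected to stay close to compound 1, with a step of a number 0.09 log units lower from compound 1 to compound 3 (within the scatter). The estimate for compound 3 is 5.9, within a range from 5.2 to 6.6.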

Compound 3, logarithm of the reciprocal of the active concentration, log(1/C): 4.37
Beside the measured number, compound 3's estimate is 1.53 log units above it, outside the stated range (below it).
By their numbers in this assay, from the lowest: compound 3; then compounds 2 and 1 (each within the scatter of the next).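

At this oxygen on an aromatic ring, in this assay, the group carried matters: (4-fluorophenyl)carbamoyl in place of methyl gives a number 1.62 log units lower from compound 1 to compound 3 (beyond the scatter), a large loss. The earlier pair gave no sign of this, since a number 0.07 log units lower from compound 1 to compound 2 (within the scatter), with (furan-2-yl)carbonyl in place of methoxy, stayed within the scatter, so a large substituent at this site of the shared core is not lost on by itself in every case. No measurement here bears on what lies behind the drop.

Which part of the entering group carries the loss stays open: the amide hydrogen, the carbonyl or the 4-fluorophenyl ring. An acetyl or a dimethylcarbamoyl group on the same oxygen would help to separate these parts.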